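The compounds below may be only part of what the source reports. "The series", "measured", "known", "first", "only" and "open" are said of these compounds alone.

Measured compounds:
compound 1, `CC/N=C(\S)NCCCCCCn1nc(-c2ccccc2)ccc1=O`, -5.6%
compound 2, `CC/N=C(/NC#N)NCCCn1nc(C)ccc1=O`, 34.5%

In a functional assay on the whole organism with Rattus norvegicus as the target, at a dose of 100 mg/kg (on this read-out higher numbers stand for more inhibition at the one dose given (going by the name of the read-out) and lower numbers for less inhibition), compound 1 gives -5.6%, the lower of the two numbers recorded; compound 2 gives 34.5%, a value that lies above it by a gap beyond the usual scatter. Compound 3, `CC/N=C(\S)NCCCCn1nc(-c2ccccc2)ccc1=O`, has not yet been measured. It differs from compound 1 in one respect: a group of 6 heavy atoms (3 carbon, 2 nitrogen, 1 sulfur; no ring) in place of a group of 8 heavy atoms (5 carbon, 2 nitrogen, 1 sulfur; no ring), on a saturated chain carbon, four bonds along the chain from an aromatic nitrogen. Among the compounds with values here, no pair of measured compounds differing in this one place exists, so the data give no measured step of this kind to lean on, and compound 2 differs from both in several places at once. The expectation for compound 3 is therefore a modest step upward from compound 1, of the size a number 13.6 percentage points higher from compound 1 to compound 3 (beyond the scatter), within or near the scatter in this assay. Compound 3 is expected to give about 8% in this assay, in the range from -15% to 35%.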

Compound 3, a percentage reported as inhibition, in the whole organism at one dose (the size of the read-out at that dose, not a potency): 67.7%
Beside the measured number, compound 3's estimate is 59.7 percentage points below it; measured number above the stated range.
By their numbers in this assay, from the lowest: compound 1; then compound 2; then compound 3.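

In this assay, the position on a saturated chain carbon, four bonds along the chain from an aromatic nitrogen, proves highly sensitive: a group of 6 heavy atoms (3 carbon, 2 nitrogen, 1 sulfur; no ring) in place of a group of 8 heavy atoms (5 carbon, 2 nitrogen, 1 sulfur; no ring) gives a number 73.3 percentage points higher from compound 1 to compound 3 (beyond the scatter). Within the data shown here, this is the first measured step at this position, and the large change comes although the two groups have the same printed counts of double bonds, donors and acceptors and the same net charge. Nothing in the available data explains why the step is so large.

The compounds shown leave open how a longer chain or an amine in place of the sulfur would read at this position. They also leave open whether a step of this size would recur on a different core.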